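A few compounds are considered here, and "the series" means these few. Any claim that something is new, unique, unknown or untested is made for them only; others in the source may bear on it.

Measured so far:

- compound 1, `CC[C@H](C)[C@H](NC(=O)CN(c1ncnc2c1ncn2C1CCCCO1)C1CC1)C(=O)OCc1ccccc1`: 25.6%
- compound 2, `CCOC(=O)CN(c1nc(Cl)nc2c1ncn2C1CCCCO1)C1CC1`: 9.92%
- compound 3, `NC(=O)CC[C@H](NC(=O)CN(c1nc(Cl)nc2[nH]cnc12)C1CC1)C(=O)OCc1ccccc1`: 30.8%

All three numbers come from a functional assay on the whole organism (Tail, strain ICR) with Mus musculus as the target, in the tail flick test, with a stated time of 30 min, at a dose of 25 umol/kg by the oral route; a higher number here means a stronger effect of the compound at the dose given, a lower number a weaker effect. Among them compound 1 stands second of three. Compound 3 is its nearest neighbour, and the two values lie within the usual scatter of each other, so they cannot be told apart. Compound 2 lies clearly lower than compound 1, by a gap beyond the scatter.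

Compound 4, `CC(C)C[C@H](NC(=O)CN(c1ncnc2c1ncn2C1CCCCO1)C1CC1)C(=O)OCc1ccccc1`, has the same atoms as compound 1, joined differently: isobutyl in place of sec-butyl on a saturated chain carbon bound to an amide-type nitrogen and a carbonyl carbon. Both groups are four-carbon chains without rings, donors or acceptors; the chain merely branches at a different point. Among the compounds with values here, no pair of measured compounds that differ in a single place is available to show how such a rearrangement plays out here.

For this reason the step from compound 1 to compound 4 in this assay is expected to be small, a number 0.6 percentage points lower from compound 1 to compound 4 (within the scatter), with no direction beyond the scatter. Compound 4 is expected to give about 25%, estimated to lie between 12% and 40%.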

Compound 4, a percentage reported as activity, at one dose (the size of the read-out at that dose, not a potency): 26.2%
Estimate against measurement, compound 4: 1.2 percentage points below; the measured number falls inside the stated range.
By their numbers in this assay, from the lowest: compound 2; then compounds 1, 4 and 3 (each within the scatter of the next).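

In this assay, isobutyl in place of sec-butyl on a saturated chain carbon bound to an amide-type nitrogen and a carbonyl carbon gives a number 0.6 percentage points higher from compound 1 to compound 4 (within the scatter) and so leaves the read-out indistinguishable between the two compounds. This is the only pair shown that differs in a single place, and it shows that, at this position, shifting the branch point of a four-carbon chain and losing the defined stereocentre of the sec-butyl group produce no detectable difference in this whole-animal test at this dose. No independent measurement here explains why the two chains read alike.

On these data alone, both chains are four-carbon groups without rings, so the effect of a longer chain, a phenyl ring, an amine or a carboxylic acid at this position remains open. A single pair also cannot show whether the same holds on a different core.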